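A Pyridyl Swap in a Series Sitting at the Limit

The source may hold more compounds than are shown below. What is called first, only, known or untested is meant among the compounds shown, and "the series" means these compounds.

Measured so far in a functional assay on cells (Rhabdomyosarcoma cell, Homo sapiens) for cytotoxicity; on this read-out lower numbers stand for stronger inhibition and higher numbers for weaker inhibition:
Compound 1 `Cc1ccsc1C(c1c(C)noc1C)N1CCN(c2ncnc3c2cnn3-c2ccccc2)CC1` gives > 25000 nM, which is a limit of the assay and not a number.
Compound 2 `Cc1noc(C)c1C(c1ccccc1)N1CCN(c2ncnc3c2cnn3-c2ccccc2)CC1` gives > 25000 nM, again a limit of the assay.
Compound 3 `Cc1ccsc1C(c1ccccc1Br)N1CCN(c2ncnc3c2cnn3-c2ccccc2)CC1` gives > 25000 nM, also a limit of the assay.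

Going by the values given here, compound 2 therefore stands where every compound measured so far stands: at the limit of > 25000 nM in this assay, at which 3 of the 3 values shown sit. Among the compounds with values here, no compound in the set produced a readable number, so the step that the two limits leave unreadable from compound 1 to compound 2 and the step that the two limits leave unreadable from compound 1 to compound 3 cannot be sized; the assay only tells that none of the three reached the cut-off from either side.

Compound 4 `c1ccc(C(c2ccccn2)N2CCN(c3ncnc4c3cnn4-c3ccccc3)CC2)cc1` is the next compound to be tested. Compared with compound 2 it carries pyridin-2-yl in place of 3,5-dimethyl-1,2-oxazol-4-yl on a saturated chain carbon bound to an amine nitrogen in a ring and an aromatic carbon. The two measured steps that change groups on the same carbon bear on this swap only in the sense that neither moved a compound off the limit. With nothing in the set having given a number, the step that the limit leaves unreadable from compound 2 to compound 4 is expected to be none beyond the scatter. Compound 4 is therefore estimated at 30000 nM in this assay, with a range from 10000 nM to 100000 nM, and most likely another limit rather than a number.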

Compound 4, half-maximal inhibitory concentration: > 25000 nM
Compound 4 ended at the assay's limit; the forecaster's own chance of this, stated with the estimate: 80%; the middle value does not contradict the limit.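

Compound 2 and compound 4 each give only a limit of the assay and not a number, so the step between them cannot be read: the limit of > 25000 nM in this assay, at which 4 of the 4 values shown sit.

The compounds shown leave open whether any swap of groups on this saturated chain carbon changes the effect on these cells at all, and how strong any of them really is.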